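Ring epimer of compound 1: expected cytotoxicity

The source may hold more compounds than are shown below. What is called first, only, known or untested is meant among the compounds shown, and "the series" means these compounds.

compound 1 `COC(=O)[C@H](C)[C@H]1CC[C@@](C)(CCC2=C(C)C(=O)CCC2(C)C)OO1` — > 10 ug/mL
compound 2 `CC1=C(CC/C(C)=C/CC[C@@]2(C)CC[C@@H]([C@H](C)C(=O)O)OO2)C(C)(C)CCC1` — 0.28 ug/mL
compound 3 `COC(=O)[C@H](C)[C@@H]1CC[C@@](C)(CCC2=C(C)C(=O)CCC2(C)C)OO1` — not yet measured

In a functional assay on L5178Y cells (Mus musculus) for cytotoxicity, read by MTT assay (on this read-out lower numbers stand for an effect already at smaller amounts and higher numbers for an effect only at larger amounts of compound), compound 1 reaches only the limit of the assay, > 10 ug/mL, not a number. In this assay compound 2 gives 0.28 ug/mL. Compound 1 thus stands at the limit of > 10 ug/mL in this assay, at which 1 of the 2 values shown sits. For the measured compounds named here, compound 3 differs from compound 1 only in configuration. the two compounds have the same atoms and bonds and differ only in configuration as drawn: 1 of 3 stereo elements differ; a stereocentre at a saturated ring carbon is drawn R in compound 1 and S in compound 3 No measured pair shows a step of this kind, so the direction of the step from compound 1 to compound 3 in this assay is open; a step of no more than the scatter is expected, a step that the limit leaves unreadable from compound 1 to compound 3. Compound 3 is expected to give 15 ug/mL, between 4 ug/mL and 50 ug/mL, most likely again only a limit.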

Compound 3, half-maximal effective concentration: < 3 ug/mL
Compound 3: no number, only a limit (the forecaster's own chance of this, stated with the estimate: 60%); middle value at least 5.0-fold (0.69 log units) away from the limit.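

In this assay, changing one stereocentre at a saturated ring carbon from R to S gives an at least 3.3-fold lower number from compound 1 to compound 3 (0.52 log units; beyond the scatter). For the compounds shown here, no earlier pair could show this: configuration at this ring carbon alone moves the read-out, with nothing entering or leaving: the fact that compounds 1 and 3 differ only in the configuration as drawn Both ends of the step are limits and not numbers, so its true size stays unread.

Still open, on these data alone, is whether the same change at this ring carbon gives a similar step with an amide in place of the methyl ester. As far as these compounds go, the effect of changing either of the other two stereo elements also remains open.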